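Chloro in place of methoxy, from a limit

This account rests on a few compounds, and the source may have more. Where it says the series, first, only, none or still open, it means among the compounds named here.

Of the compounds shown here, two on the shared core have been read in a functional assay on OVCAR-3 cells (Homo sapiens) for antiproliferative activity, read by spectrophotometry, with a stated time of 2 days; a lower number here means a stronger inhibitor of growth, a higher number a weaker inhibitor of growth: compound 1 (`COc1ccc(C(F)(F)F)cc1Nc1ncc(C(F)(F)F)c(N2Cc3cccc(N(C)S(C)(=O)=O)c3C2)n1`) and compound 2 (`COc1cc(Nc2ncc(C(F)(F)F)c(N3Cc4cccc(N(C)S(C)(=O)=O)c4C3)n2)cc(C(F)(F)F)c1`). Compound 1 gives > 30000 nM, a limit of the assay and not a number. Compound 2 gives > 30000 nM, again a limit and not a number. Compound 2 therefore stands with compound 1 at the limit of > 30000 nM in this assay, at which 2 of the 2 values shown sit.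

Among the measured compounds shown here, the one measured step is a step that the two limits leave unreadable from compound 1 to compound 2, so it offers no size to carry forward.

Compound 3 (`CN(c1cccc2c1CN(c1nc(Nc3cc(Cl)cc(C(F)(F)F)c3)ncc1C(F)(F)F)C2)S(C)(=O)=O`) has chloro in place of methoxy on an aromatic carbon, meta to a trifluoromethyl group, which gives 3-chloro-5-(trifluoromethyl)phenyl: chloro in place of methoxy on an aromatic carbon. For the measured compounds named here, no measured step replaces the methoxy with another group. In this assay, no clear gain in growth inhibition is expected, and no direction can be argued from the data. That expectation rests on compound 2, whose > 30000 nM is a limit. The expected step is an at least 1.2-fold lower number from compound 2 to compound 3 (0.07 log units; that floor lies within the scatter), an estimate held loosely. A report of only a limit is the likeliest outcome. For compound 3 the estimated value is 25000 nM, with an expected range of 8000 nM to 60000 nM.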

Compound 3, concentration for 50% growth inhibition: 21500 nM
Compound 3: middle estimate off by 1.2-fold (0.07 log units), on the high side; measured number inside the range.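

In this assay, among the compounds shown here, chloro in place of methoxy on an aromatic carbon meta to a trifluoromethyl group gives the first number on the shared core rather than a limit, with an at least 1.3-fold lower number from compound 2 to compound 3 (0.14 log units; that floor lies within the scatter). Read from the other methoxy compound, the change to 3-chloro-5-(trifluoromethyl)phenyl gives an at least 1.3-fold lower number from compound 1 to compound 3 (0.14 log units; that floor lies within the scatter), so both steps have only a floor, neither floor establishes a gain beyond the scatter, and the step between the two methoxy compounds cannot be read. Compound 2 has a limit of the assay and not a number, so the true size of its step to compound 3 stays unknown: the limit of > 30000 nM in this assay, at which 2 of the 3 values shown sit.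

Still open, from the compounds shown here alone, is whether another group on this aromatic carbon, such as a nitrile, an amine or a carboxylic acid, would move the number clearly beyond the scatter from that of compound 3. The compounds shown also leave open whether chloro at this place would keep a readable number with a different group in place of the trifluoromethyl group, or with changes elsewhere on the shared core.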